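Furan amide series: pyridyl isomer of compound 3

The compounds below may be only part of what the source reports. "The series", "measured", "known", "first", "only" and "open" are said of these compounds alone.

Of the compounds shown here, three of the shared core have been measured in an assay on T47D cells for inhibition of 17-beta-hydroxysteroid dehydrogenase type 1 (Homo sapiens), read by HPLC, with a stated time of 24 h; on this read-out lower numbers stand for stronger inhibition and higher numbers for weaker inhibition. Compound 1 `Cc1ccccc1N(C)C(=O)c1ccc(-c2ccc(O)cc2)o1` gives 21 nM, compound 2 `Cc1c(F)cccc1N(C)C(=O)c1ccc(-c2ccc(O)cc2)o1` gives 50 nM, and compound 3 `Cc1cccnc1N(C)C(=O)c1ccc(-c2ccc(O)cc2)o1` gives 1100 nM. Compound 3 stands highest of the three numbers: the steps of a 52-fold higher number from compound 1 to compound 3 (1.72 log units; beyond the scatter) and a 22-fold higher number from compound 2 to compound 3 (1.34 log units; beyond the scatter) both lie well beyond the scatter, whereas the step of a 2.4-fold higher number from compound 1 to compound 2 (0.38 log units; beyond the scatter) is only modest.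

Compound 4 `Cc1ncccc1N(C)C(=O)c1ccc(-c2ccc(O)cc2)o1` differs from compound 3 solely in the ring on the amide-type nitrogen: 2-methylpyridin-3-yl in place of 3-methylpyridin-2-yl on an amide-type nitrogen. Among the compounds with values here, no measured step covers an exchange of one pyridyl isomer for another. Within the data shown here, the steps that bear on it, a 52-fold higher number from compound 1 to compound 3 (1.72 log units; beyond the scatter) and a 22-fold higher number from compound 2 to compound 3 (1.34 log units; beyond the scatter), show only that a pyridyl in place of a phenyl at this position raises the number by a large amount; compound 4 keeps a pyridyl, so no step beyond the scatter is expected in this assay, and the expected step is a 1.4-fold lower number from compound 3 to compound 4 (0.14 log units; within the scatter). Compound 4 is therefore estimated at 800 nM, with a wide range from 150 nM to 4000 nM.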

Compound 4, half-maximal inhibitory concentration: 43 nM
Compound 4: the middle estimate sits 19-fold (1.27 log units) above what was measured; the whole stated range lies above it.
By their numbers in this assay, from the lowest: compound 1; then compounds 4 and 2 (each within the scatter of the next); then compound 3.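

In this assay a pyridyl on the amide-type nitrogen does not by itself carry the large rise seen with compound 3: the two isomers hold the same atoms, joined differently, yet they are far apart (a 26-fold lower number from compound 3 to compound 4 (1.41 log units; beyond the scatter)). The 2-methylpyridin-3-yl ring stays close to both phenyl rings, within the scatter of the fluorinated one (a 1.2-fold lower number from compound 2 to compound 4 (0.07 log units; within the scatter)) and only a modest step from the unfluorinated one (a 2.0-fold higher number from compound 1 to compound 4 (0.31 log units; beyond the scatter)). Nothing available explains the gap between the two isomers.

The compounds shown leave open whether the methyl on the pyridyl ring matters, as an unsubstituted pyridin-3-yl or an ethyl in its place would test. They also leave open how a pyrimidinyl ring would behave at this position.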